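From benzyloxy to butoxy: what compound 4 may do

A few compounds are considered here, and "the series" means these few. Any claim that something is new, unique, unknown or untested is made for them only; others in the source may bear on it.

Measured in an ADME assay on KB cells (Homo sapiens) for cytotoxicity; on this read-out lower numbers stand for an effect already at smaller amounts and higher numbers for an effect only at larger amounts of compound:
- Compound 1 `COc1cc2c(c(OCc3ccccc3)c1OC)C(=O)[C@]1(OC)C=C[C@H]2N(C(=O)OCC(C)C)N1C(=O)OCC(C)C`: 94 ug/mL
- Compound 2 `CCCOc1c(OC)c(OC)cc2c1C(=O)[C@]1(OC)C=C[C@H]2N(C(=O)OCC)N1C(=O)OCC`: > 300 ug/mL
- Compound 3 `CCOC(=O)N1[C@@H]2C=C[C@@](OC)(C(=O)c3c2cc(OC)c(OC)c3OCc2ccc(Cl)cc2)N1C(=O)OCC`: 99.9 ug/mL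

Compound 1 at 94 ug/mL and compound 3 at 99.9 ug/mL lie within the scatter of each other. The entry for compound 2 is a limit, not a number.

Compound 4 `CCCCOc1c(OC)c(OC)cc2c1C(=O)[C@]1(OC)C=C[C@H]2N(C(=O)OCC(C)C)N1C(=O)OCC(C)C` has propyl in place of phenyl on a saturated chain carbon bound to an oxygen on an aromatic ring. Within the data shown here, one measured step bears on this, in the opposite sense: 4-chlorophenyl replaced ethyl, giving an at least 3.0-fold lower number from compound 2 to compound 3 (0.47 log units; beyond the scatter). Losing the aromatic ring should therefore move the number up, though that ring also carried chlorine and only one step supports this. The expected change is a 1.9-fold higher number from compound 1 to compound 4 (0.28 log units; within the scatter). For compound 4 the estimated value is 180 ug/mL, with an expected range of 70 ug/mL to 400 ug/mL.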

Compound 4, concentration for half-maximal effect: 22.1 ug/mL
For compound 4 the middle estimate is 8.1-fold (0.91 log units) above the measured one, and the stated range ends above it.
By their numbers in this assay, from the lowest: compound 4; then compounds 1 and 3 (each within the scatter of the next). At a limit, above all of these: compound 2.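

In this assay, butoxy in place of benzyloxy gives a 4.3-fold lower number from compound 1 to compound 4 (0.63 log units; beyond the scatter), so at this position an aromatic ring is not needed for a low number. Losing the ring here lowers the number, the reverse of what was suggested by an at least 3.0-fold lower number from compound 2 to compound 3 (0.47 log units; beyond the scatter). Compound 2, where that earlier step starts, stands at a limit, not a number: the limit of > 300 ug/mL in this assay, at which 1 of the 4 values shown sits.

On these data alone, whether a longer chain such as hexyl would lower the number further stays open, as does the effect of a chain carrying an amine. Also open, as far as these compounds go, is how much of the earlier step belongs to the chlorine rather than to the ring.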